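Moving the nitrile on the sulfonyl aryl of compound 1

The compounds below may be only part of what the source reports. "The series", "measured", "known", "first", "only" and "open" are said of these compounds alone.

In an assay on isolated protein for displacement of a labelled ligand from metabotropic glutamate receptor 5 (Homo sapiens), with a stated time of 60 min, tested at 1 uM (on this read-out higher numbers stand for more inhibition at the one concentration tested (going by the name of the read-out) and lower numbers for less inhibition), compound 1 `CC1CCN(c2c(S(=O)(=O)c3ccc(C#N)cc3)cnc3cc(Cl)ccc23)CC1` gives 70%, the second highest of the three numbers shown. Compound 2 `CC1CCN(c2c(S(=O)(=O)c3ccc(C#N)cc3)cnc3cc(F)ccc23)CC1` gives 83%, and the step of a number 13 percentage points higher from compound 1 to compound 2 (beyond the scatter) lies beyond the scatter. Compound 3 `COc1ccc(S(=O)(=O)c2cnc3ccc(Cl)cc3c2N2CCC(C)CC2)cc1Cl` gives 46%, lower than compound 1 beyond the scatter. Compound 4 `CC1CCN(c2c(S(=O)(=O)c3cccc(C#N)c3)cnc3cc(Cl)ccc23)CC1` differs from compound 1 by 3-cyanophenyl in place of 4-cyanophenyl on a sulfonyl sulfur. Going by the values given here, the only measured single-point step, a number 13 percentage points higher from compound 1 to compound 2 (beyond the scatter), concerns the shared core and not the sulfonyl aryl, so no measured step bears directly on this change; the expectation is therefore a step near or within the scatter, if anything a modest fall. Compound 4 is estimated to give 60%, within 35% to 80%. This expected change corresponds to a number 10 percentage points lower from compound 1 to compound 4 (within the scatter).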

Compound 4, a percentage reported as inhibition, at one concentration (the size of the read-out at that concentration, not a potency): 94%
The estimate for compound 4 lay 34 percentage points below the measured number; measured number outside the range, above it.
By their numbers in this assay, from the lowest: compound 3; then compound 1; then compound 2; then compound 4.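

In this assay the step of a number 24 percentage points higher from compound 1 to compound 4 (beyond the scatter) shows that 3-cyanophenyl in place of 4-cyanophenyl on a sulfonyl sulfur is enough on its own to move the read-out, although the two compounds hold the same atoms. Going by these compounds alone, the only earlier single-place step concerned the shared core, so this is the first sign that the sulfonyl aryl responds to change. Nothing at hand explains the rise.

From the compounds shown here alone, whether 3-cyanophenyl gives a similar step on the core of compound 2 remains open. So does what an amine or a carboxylic acid would give in place of the nitrile.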